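The source may hold more compounds than are shown below. What is called first, only, known or untested is meant among the compounds shown, and "the series" means these compounds.

In a functional assay on HT-29 cells (Homo sapiens) for cytotoxicity, read by MTT assay, with a stated time of 24 h (on this read-out lower numbers stand for stronger inhibition and higher numbers for weaker inhibition), compound 1 `C#CCOc1ccccc1/C=N/Cc1ccc(S(N)(=O)=O)cc1` gives 31000 nM. Compound 2 `C#CCOc1c(/C=N/Cc2ccc(S(N)(=O)=O)cc2)cccc1OC` carries methoxy in place of hydrogen on an aromatic carbon and in this assay compound 2 gives 81300 nM, so this change brought a 2.6-fold higher number from compound 1 to compound 2 (0.42 log units; beyond the scatter). Compound 3 `NS(=O)(=O)c1ccc(C/N=C/c2ccccc2OCc2cn(CCCOc3ccc4ccc(=O)oc4c3)nn2)cc1` rests on a different core; how its core differs from that of compound 1 is not broken down here. In this assay compound 3 gives 14300 nM. Compound 4 `COc1cccc(/C=N/Cc2ccc(S(N)(=O)=O)cc2)c1OCc1cn(CCCOc2ccc3ccc(=O)oc3c2)nn1` differs from compound 3 by methoxy in place of hydrogen on an aromatic carbon. This is the same kind of change as from compound 1 to compound 2, though the surroundings differ: in compound 2 the methoxy stands ortho to a propargyloxy group, whereas in compound 4 it stands ortho to a large group. For compound 4 a step of similar size is expected, a 2.5-fold higher number from compound 3 to compound 4 (0.40 log units; beyond the scatter), because the same kind of change gave a 2.6-fold higher number from compound 1 to compound 2 (0.42 log units; beyond the scatter). Compound 4 is therefore estimated at 36000 nM, expected to fall between 14000 nM and 90000 nM.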

Compound 4, half-maximal inhibitory concentration: 52500 nM
The estimate for compound 4 lay 1.5-fold (0.16 log units) below the measured number, and the stated range covers the measured number.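

Putting methoxy in place of hydrogen on an aromatic carbon again gave weaker inhibition in this assay, with a 3.7-fold higher number from compound 3 to compound 4 (0.56 log units; beyond the scatter). The size of the step held when the change moved to a different core, and the two steps cannot be told apart: the same change on two cores in this assay, a 2.6-fold higher number (0.42 log units; beyond the scatter) from compound 1 to compound 2 and a 3.7-fold higher number (0.56 log units; beyond the scatter) from compound 3 to compound 4, 1.4-fold (0.15 log units) apart, within the scatter of two such steps. Among the compounds shown here, this shows only that the change carried over between these two cores in this one assay; two pairs do not establish a rule for the series, and they do not explain why the number rises.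

As far as these compounds go, it remains open how a hydroxyl, an amine or a longer ether chain on that same aromatic carbon would behave. From the compounds shown here alone, it also remains open whether the methoxy step would hold on other cores.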